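Swapping Trifluoromethyl for Methoxy on an Aromatic Ring

A few compounds are considered here, and "the series" means these few. Any claim that something is new, unique, unknown or untested is made for them only; others in the source may bear on it.

Among the compounds with values here, in a functional assay on OCI-Ly3 cells (Homo sapiens) for inhibition, read by CellTiter-Glo, with stated times of 48 h and 96 h (on this read-out lower numbers stand for stronger inhibition of growth and higher numbers for weaker inhibition of growth), compound 2 `CC(C)[C@H](NC(=O)c1ccc(C(F)(F)F)cc1)C(=O)N1CCC[C@H]1C(=O)N[C@@H](CCCNC(=N)N)C(=O)CF` gives 120 nM, the lower of the two numbers so far, and compound 1 `CC(C)[C@H](NC(=O)c1ccccc1)C(=O)N1CCC[C@H]1C(=O)N[C@@H](CCCNC(=N)N)C(=O)CF` gives 660 nM. Compound 3 `COc1ccc(C(=O)N[C@H](C(=O)N2CCC[C@H]2C(=O)N[C@@H](CCCNC(=N)N)C(=O)CF)C(C)C)cc1` carries methoxy in place of trifluoromethyl on an aromatic carbon. Within the data shown here, the only measured step that bears on this is a 5.5-fold lower number from compound 1 to compound 2 (0.74 log units; beyond the scatter), where trifluoromethyl replaced hydrogen. Among the measured compounds shown here, no methoxy compound has been measured, so losing trifluoromethyl is expected to give back only part of that size, toward a higher number. The expected change is a 2.5-fold higher number from compound 2 to compound 3 (0.40 log units; beyond the scatter). For compound 3 the estimate is 300 nM, within an expected range of 100 nM to 800 nM.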

Compound 3, concentration for 50% growth inhibition: 1670 nM
Estimate against measurement, compound 3: 5.6-fold (0.75 log units) below; the measured number lies above the stated range.
By their numbers in this assay, from the lowest: compound 2; then compound 1; then compound 3.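

In this assay the swap gives a 14-fold higher number from compound 2 to compound 3 (1.14 log units; beyond the scatter), so this position on the aromatic ring can move growth inhibition strongly in either direction. Methoxy does more than lose what trifluoromethyl gained: against plain hydrogen it gives a 2.5-fold higher number from compound 1 to compound 3 (0.40 log units; beyond the scatter), which places compound 3 behind compound 1, while trifluoromethyl had placed compound 2 ahead of it. No available evidence explains why these two groups pull in opposite directions. Still open, from the compounds shown here alone, is where an amine, a carboxylic acid or a chlorine atom would fall in this order, and whether the same order holds at other carbons of the ring.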